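Methyl to isopropyl on the saturated chain carbon

A few compounds are considered here, and "the series" means these few. Any claim that something is new, unique, unknown or untested is made for them only; others in the source may bear on it.

Of the compounds shown here, three have been measured in an assay for inhibition of beta-glucuronidase (Bos taurus), read by spectrophotometry, with a stated time of 30 min; on this read-out higher numbers stand for weaker inhibition and lower numbers for stronger inhibition. Compound 1 `COC(=O)C1=C(C)NC(=O)NC1c1ccccc1OC` gives 59200 nM in this assay. Compound 2 `COC(=O)C1=C(C)NC(=O)NC1c1ccc(O)c(Cl)c1` gives 27200 nM in this assay. Compound 3 `CCC1NC(=O)NC(C)=C1C(=O)OC` gives 52200 nM in this assay. The three numbers lie within the scatter of one another; compound 3 sits among them, its number nearest to that of compound 1, while the gap to compound 2 is the widest of the three yet still inside the scatter. Among the compounds with values here, no single-point comparison between the measured compounds is available, so no measured step sets a precedent for the next change.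

Compound 4 `COC(=O)C1=C(C)NC(=O)NC1CC(C)C` differs from compound 3 in one place: isopropyl in place of methyl on a saturated chain carbon bound to a saturated ring carbon. The aryl groups of compound 1 and compound 2 give no guidance here, since the change at hand stays within a saturated chain. With nothing in the measured set pointing either way, the step from compound 3 to compound 4 in this assay is expected to be small and in no particular direction, no larger than the scatter, as a 1.0-fold lower number from compound 3 to compound 4 (0.02 log units; within the scatter) expresses. For compound 4 the estimate in this assay is 50000 nM, with a range from 20000 nM to 125000 nM.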

Compound 4, half-maximal inhibitory concentration: 55200 nM
Compound 4: middle estimate off by 1.1-fold (0.04 log units), on the low side; low and high end bracket the measured number.
By their numbers in this assay, from the lowest: compounds 2, 3, 4 and 1 (each within the scatter of the next, the first and the last beyond it).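

In this assay the series now has its first step that differs in one place, and it reads a 1.1-fold higher number from compound 3 to compound 4 (0.02 log units; within the scatter), so methyl and isopropyl on a saturated chain carbon bound to a saturated ring carbon are not told apart by this read-out. Read one bond further out, the same difference is ethyl to isobutyl, and the move from 1 heavy atom to 3 heavy atoms at this place leaves the two compounds within the scatter of each other, something the earlier compounds, with no single-place comparison among them, could not show. No measurement at hand bears on why compound 3 and compound 4 read alike.

The compounds shown speak for methyl and isopropyl at this place only, and no rule for the chain as a whole follows from this single step. Going by these compounds, whether a longer chain such as n-hexyl, an amine or a carboxylic acid on the chain would separate from these two compounds beyond the scatter remains open.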